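This account rests on a few compounds, and the source may have more. Where it says the series, first, only, none or still open, it means among the compounds named here.

Compound 1, `Cn1cc(C(=O)N2CCc3nc(COc4ccccc4)oc3C2)c2ccccc21`, in this assay: 70%
Compound 2, `CC1c2oc(COc3ccccc3)nc2CCN1C(=O)c1ccc(F)cc1`, in this assay: 70%

In a functional assay on HEK293 cells for positive allosteric modulation of metabotropic glutamate receptor 5 (Homo sapiens), read by calcium flux (a higher number here means a larger maximal response, a lower number a smaller maximal response), compound 1 reaches 70% and compound 2 reaches 70%, so compound 2 stands level with compound 1, the gap lying within the usual scatter of such measurements. Compound 3, `CC1(C)c2oc(COc3ccccc3)nc2CCN1C(=O)c1ccc(F)cc1`, is the next compound and differs from compound 2 by methyl in place of hydrogen on a saturated ring carbon. Within the data shown here, no measured pair shows this change, so its effect is unknown from these data. A small step is expected, a number 7 percentage points lower from compound 2 to compound 3 (within the scatter), not clearly beyond the scatter and if anything downward. Compound 3 is estimated at 63%, with a range from 35% to 90%.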

Compound 3, largest response reached (reported as percent of maximum), in percent of the reference or control that the assay uses: 61%
Beside the measured number, compound 3's estimate is 2 percentage points above it; low and high end bracket the measured number.
By their numbers in this assay, from the lowest: compounds 3, 1 and 2 (each within the scatter of the next).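

Methyl in place of hydrogen on this saturated ring carbon, next to the ring nitrogen, gives a number 9 percentage points lower from compound 2 to compound 3 (within the scatter) in this assay, so a second methyl on a carbon already bearing one keeps the maximal response within the usual scatter. Among these compounds, this is the first reading of this change at this position, and it rests on a single pair. Nothing measured here offers an explanation for the result.

Going by these compounds, whether an ethyl group or an amine on the same carbon would also keep the response within the scatter stays open. So does the effect of such a change with a different group on the ring nitrogen.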